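The compounds below may be only part of what the source reports. "The series", "measured", "known", "first", "only" and "open" are said of these compounds alone.

Working notes on solubility. Compound 1 `CC(C)(C)c1nc(C2CCCC2)c2c(N)c(C#N)c(N)nc2n1` gives, in a physicochemical assay for solubility, in phosphate buffer, with a stated time of 18 h (on this read-out higher numbers stand for higher solubility and lower numbers for lower solubility), a reading that is a limit of the assay rather than a number, < 1000 nM. Compound 2 `CC(C)(C)c1nc(-c2ccsc2)c2c(N)c(C#N)c(N)nc2n1` gives in this assay 40000 nM. For the measured compounds named here, compound 2 thus holds the only numerical value in the set, the other reading being a limit. Going by the values given here, the single measured step, an at least 40-fold higher number from compound 1 to compound 2 (1.60 log units; beyond the scatter), involves (the limit of < 1000 nM in this assay, at which 1 of the 2 values shown sits).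

Compound 3 `CC(C)(C)c1nc(-c2nc(CO)cs2)c2c(N)c(C#N)c(N)nc2n1` is not yet measured in this assay. It differs from compound 2 as follows: 4-(hydroxymethyl)-1,3-thiazol-2-yl in place of thiophen-3-yl on an aromatic carbon. Among the compounds with values here, no measured step covers this exchange; the step from compound 1 to compound 2 concerns a different replacement at the same place and shows only that an exchange there can move this assay strongly. Nothing among the numbers fixes a direction for compound 3, so no step beyond the scatter is assumed, with wide uncertainty on either side. Compound 3 is expected to give 60000 nM, within 20000 nM to 200000 nM. The expected step is a 1.5-fold higher number from compound 2 to compound 3 (0.18 log units; within the scatter).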

Compound 3, solubility: < 1000 nM
Compound 3: no number, only a limit; the forecaster's own chance of this, stated with the estimate: 10%; middle value at least 60-fold (1.77 log units) from the limit.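

In this assay, 4-(hydroxymethyl)-1,3-thiazol-2-yl in place of thiophen-3-yl gives an at least 40-fold lower number from compound 2 to compound 3 (1.60 log units; beyond the scatter). The earlier pair set thiophen-3-yl against cyclopentyl only; compound 3 now shows that a five-membered aromatic ring at this position, on the aromatic carbon opposite the ring nitrogen, does not by itself go with the high reading of compound 2, so compound 3 stands against any simple link between an aromatic ring here and a high number. The step between compound 1 and compound 3 cannot be read, and compound 2 remains the only compound with a number, the other two readings being limits of the assay: the limit of < 1000 nM in this assay, at which 2 of the 3 values shown sit.

The compounds shown leave open whether the low reading of compound 3 goes with the ring with 2 hetero atoms or with the hydroxymethyl group, as the two enter together and neither appears alone. They also leave open how this assay responds at this position to a basic amine such as aminomethyl or to a carboxylic acid on the five-membered ring.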